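The source may hold more compounds than are shown below. What is called first, only, known or untested is meant among the compounds shown, and "the series" means these compounds.

Three compounds of the series share one core. Compound 1 `CCCCc1cc(C(C)=O)c(O)cc1OCCCCC#N` gives 13% in an assay on isolated protein for binding affinity to leukotriene B4 receptor 1 (Homo sapiens), tested at 1 uM; on this read-out higher numbers stand for more inhibition at the one concentration tested (going by the name of the read-out) and lower numbers for less inhibition; compound 2 `CCCCCCc1cc(C(C)=O)c(O)cc1OCCCCC#N` gives 13% in this assay, and the step is no change at the digits printed from compound 1 to compound 2 (within the scatter). Compound 3 `CC(=O)c1cc(CC2CO2)c(OCCCCC#N)cc1O` gives 24% in this assay, the highest of the three numbers; the steps to it are a number 11 percentage points higher from compound 1 to compound 3 (beyond the scatter) and a number 11 percentage points higher from compound 2 to compound 3 (beyond the scatter).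

Compound 4 `CC(=O)c1cc(CC(C)O)c(OCCCCC#N)cc1O` differs from compound 3 by 1-hydroxyethyl in place of oxiran-2-yl on a saturated chain carbon bound to an aromatic carbon. Within the data shown here, no measured step bears directly on this change: the steps that exist lengthen a chain or replace a propyl or pentyl by an oxiran-2-yl, and none compares an oxiran-2-yl with a 1-hydroxyethyl. The steps into compound 3 were modest in size, and with nothing to fix a direction the expectation for compound 4 is a number near that of compound 3, with room to drift back toward the values of compound 1 and compound 2. Compound 4 is therefore estimated at 20% in this assay, range 8% to 32%. The expected step is a number 4 percentage points lower from compound 3 to compound 4 (within the scatter), which is not beyond the scatter.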

Compound 4, a percentage reported as inhibition, at one concentration (the size of the read-out at that concentration, not a potency): 6%
For compound 4 the middle estimate is 14 percentage points above the measured one; measured number below the stated range.
By their numbers in this assay, from the lowest: compounds 4, 1 and 2 (each within the scatter of the next); then compound 3.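

At this position, on a saturated chain carbon bound to an aromatic carbon, the closed oxiran-2-yl cannot be exchanged for the open 1-hydroxyethyl without consequence in this assay, as a number 18 percentage points lower from compound 3 to compound 4 (beyond the scatter) shows. The 1-hydroxyethyl does not separate from the plain alkyl chains, with a number 7 percentage points lower from compound 2 to compound 4 (within the scatter) and a number 7 percentage points lower from compound 1 to compound 4 (within the scatter) both printed as within the scatter, so among the groups shown only oxiran-2-yl stands apart. Nothing in the data available explains the difference between the closed and open groups.

Still open, from the compounds shown here alone, is whether the higher number of compound 3 depends on the three-membered ring or on the absence of a hydroxyl, which a 1-methoxyethyl or an aziridin-2-yl at the same place could begin to separate. Going by these compounds, all four numbers come from one concentration, so how these differences would translate into potency also remains open.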